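The compounds below may be only part of what the source reports. "The series", "measured", "known", "first", "only" and "open" are said of these compounds alone.

Measured compounds:
compound 1 `CN(C)CCn1cnnc1-c1cc(Oc2ccc(NC(=O)N/N=C/c3c(Cl)cccc3Cl)cc2F)ccn1`, 3320 nM;
compound 2 `CN(C)CCn1cnnc1-c1cc(Oc2ccc(NC(=O)N/N=C/c3cc(C(C)(C)C)cc(C(C)(C)C)c3O)cc2F)ccn1`, 2350 nM;
compound 3 `CN(C)CCn1cnnc1-c1cc(Oc2ccc(NC(=O)N/N=C/c3ccc(O)c(O)c3)cc2F)ccn1`, "not determined" (no result reported).

All three compounds share one core and differ only in the aromatic ring carried on the far end. In an ADME assay on WI-38 cells (Homo sapiens) for cytotoxicity, read by MTT assay, with a stated time of 72 h (a lower number here means a stronger inhibitor, a higher number a weaker inhibitor), compound 1 gives 3320 nM, and compound 2 gives 2350 nM; these two values lie within the usual scatter of each other, so no order between them can be read. Compound 3, which carries the 3,4-dihydroxyphenyl ring, stands without a number in this assay, so its own position cannot be placed against compounds 1 and 2.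

Compound 4 `COc1cc(/C=N/NC(=O)Nc2ccc(Oc3ccnc(-c4nncn4CCN(C)C)c3)c(F)c2)ccc1O` is reached from compound 3 by one change: methyl in place of hydrogen on an oxygen on an aromatic ring. Going by the values given here, no measured pair shows a step of this kind, so the size of the step in this assay cannot be taken from the data; with compound 3 itself unmeasured, the expectation for compound 4 rests on compounds 1 and 2: compound 1 gives 3320 nM and compound 2 gives 2350 nM, and these two values set the only range known for this core. Compound 4 is therefore expected to fall near that range, at an estimated 3000 nM, between 1200 nM and 9000 nM.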

Compound 4, half-maximal inhibitory concentration: 5320 nM
Estimate against measurement, compound 4: 1.8-fold (0.25 log units) below; low and high end bracket the measured number.
By their numbers in this assay, from the lowest: compounds 2, 1 and 4 (each within the scatter of the next, the first and the last beyond it).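

In this assay, 4-hydroxy-3-methoxyphenyl in place of 2,6-dichlorophenyl at this position gives a 1.6-fold higher number from compound 1 to compound 4 (0.20 log units; within the scatter), so this exchange of one aromatic ring for another does not separate the two compounds. The hydroxy to methoxy change itself cannot be read, as compound 3 has no number to set against compound 4. No measurement bears on what lies behind the value of compound 4.

As far as these compounds go, whether an amine or a carboxylic acid on this aromatic ring would shift the number beyond the scatter remains open. From the compounds shown here alone, it is also open whether a longer chain than methyl on the same oxygen, such as ethyl or propyl, would change the reading in this assay.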